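The compounds below may be only part of what the source reports. "The series", "measured", "known", "first", "only" and "open" are said of these compounds alone.

Measured so far in a functional assay on A-375 cells (Homo sapiens) for antiproliferative activity, read by MTT assay, with a stated time of 72 h; a lower number here means a stronger inhibitor, a higher number a weaker inhibitor:
Compound 1 `COc1cccc(N2C(=O)COc3ccc(-c4cnc(Cl)c(NS(=O)(=O)c5ccc(F)cc5)c4)cc32)c1`: > 40000 nM, a limit of the assay
Compound 2 `CC(C)N1C(=O)COc2ccc(-c3cnc(Cl)c(NS(=O)(=O)c4ccc(F)cc4)c3)cc21`: 25500 nM
Compound 3 `COc1ncc(-c2ccc3c(c2)N(c2ccccc2)C(=O)CO3)cc1NS(=O)(=O)c1ccc(F)cc1`: 15200 nM

Among the measured compounds shown here, compound 3 and compound 2 are the only two with true numbers, and these lie within the usual scatter of each other. Compound 1 gives only a limit.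

Compound 4 `O=C1COc2ccc(-c3cnc(Cl)c(NS(=O)(=O)c4ccc(F)cc4)c3)cc2N1c1ccccc1` has not yet been measured. It differs from compound 3 in one place: chloro in place of methoxy on an aromatic carbon. This puts chloro in place of methoxy on an aromatic carbon, next to the ring nitrogen and ortho to a ((4-fluorophenyl)sulfonyl)amino group.

For the measured compounds named here, no measured step makes this exact swap. Going by the values given here, the only measured step, an at least 1.5-fold lower number from compound 1 to compound 2 (0.19 log units; that floor lies within the scatter), puts isopropyl in place of 3-methoxyphenyl on an amide-type nitrogen, so it concerns a different part of the molecule and bears on this change only indirectly. Compound 2 already carries the chloro, and at 25500 nM compound 2 stays within the scatter of compound 3. A large gain therefore seems unlikely.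

In this assay the expected change is no more than the scatter, with a slight lean towards a higher number: an estimated 1.6-fold higher number from compound 3 to compound 4 (0.20 log units; within the scatter). For compound 4 the estimated value is 24000 nM, with an expected range from 11000 nM to 40000 nM.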

Compound 4, half-maximal inhibitory concentration: 36900 nM
Estimate against measurement, compound 4: 1.5-fold (0.19 log units) below; measured number inside the range.
By their numbers in this assay, from the lowest: compounds 3, 2 and 4 (each within the scatter of the next, the first and the last beyond it). At a limit, above all of these: compound 1.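

Among the compounds shown here, at the aromatic carbon next to the ring nitrogen and ortho to a ((4-fluorophenyl)sulfonyl)amino group, this is the first single change that can be read, and in this assay it gives a 2.4-fold higher number from compound 3 to compound 4 (0.39 log units; beyond the scatter), so with phenyl on the amide-type nitrogen, methoxy at this position beats chloro by a modest margin. Phenyl in place of isopropyl on the amide-type nitrogen in a ring gives a 1.4-fold higher number from compound 2 to compound 4 (0.16 log units; within the scatter), so this change does not separate the two chloro compounds. Compound 1 gives only a limit: the limit of > 40000 nM in this assay, at which 1 of the 4 values shown sits. The step read against that limit, an at least 1.0-fold lower number from compound 1 to compound 4 (0.03 log units; that floor lies within the scatter), therefore cannot be read as a true size.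

What an amine, a nitrile or an ethoxy group would give on this carbon stays open, since only methoxy and chloro are shown there. Also open, going by these compounds, is whether the step from methoxy to chloro keeps its size with isopropyl or 3-methoxyphenyl on the amide-type nitrogen in place of phenyl.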